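This account rests on a few compounds, and the source may have more. Where it says the series, first, only, none or still open, it means among the compounds named here.

Measured so far:
Compound 1 `O=C(Nc1ccc(Cl)cc1CN1C(=O)c2ccccc2C1=O)C1CCCCC1` gives < 1000 nM in an assay on CHO cells for positive allosteric modulation of metabotropic glutamate receptor 5 (Rattus norvegicus), read by FLIPR; on this read-out higher numbers stand for an effect only at larger amounts of compound and lower numbers for an effect already at smaller amounts; this is a limit of the assay, not a number.
Compound 2 `O=C(Nc1ccc(Cl)cc1CN1C(=O)c2ccccc2C1=O)c1cncs1` gives < 1000 nM in this assay; this too is a limit.

Compound 1 thus stands only at a limit, with no numerical value of its own; the limit of < 1000 nM in this assay, at which 2 of the 2 values shown sit, is all the evidence on this series. Among the compounds with values here, the one change measured from it, a step that the two limits leave unreadable from compound 1 to compound 2, is therefore of unknown size and direction.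

Compound 3 `O=C(Nc1ccc(Cl)cc1CN1C(=O)c2ccccc2C1=O)c1ccccc1[N+](=O)[O-]` is not yet measured. It differs from compound 1 in one place: 2-nitrophenyl in place of cyclohexyl on a carbonyl carbon. Within the data shown here, the only measured step that bears on this change is the one from compound 1 to compound 2, and that step cannot be read. No size or direction of step in this assay can thus be expected with any confidence beyond the scatter.

For compound 3 the estimate is 400 nM, in the range 60 nM to 2500 nM, which corresponds to an expected step that the limit leaves unreadable from compound 1 to compound 3.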

Compound 3, half-maximal effective concentration: < 1000 nM
Compound 3 ended at the assay's limit; the forecaster's own chance of this, stated with the estimate: 45%; the middle value is on the limit's open side.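

Within the data shown here, no step among compound 1, compound 2 and compound 3 can be read in this assay, as all three values are limits and not numbers. The size and direction of any differences among these compounds remain open: the limit of < 1000 nM in this assay, at which 3 of the 3 values shown sit.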